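The source may report more compounds than this note shows. Statements on the series, on what has been measured and on what is new or still open speak of the compounds shown alone.

Compound 1 `Cc1c(OCCCCOc2ccc(C(=O)O)cc2Cl)ccc(C(=O)CC2CCCC2)c1O` was tested in an assay on HEK293 cells for positive allosteric modulation of metabotropic glutamate receptor 3 (Rattus norvegicus), read by thallium flux, with a stated time of 2.5 min; a higher number here means that more compound is needed for the effect, a lower number that less compound is needed. In this assay compound 1 gives only a limit, > 10000 nM, which is a boundary of the measurement rather than a number. Two other compounds of the same series frame this result. Compound 3 `CCCC(=O)c1ccc(OCCCCOc2ccc(C(=O)O)cc2C)c(C)c1O` differs from compound 1 in several places at once. In this assay compound 3 also gives only a limit, > 10000 nM. Compound 2 `Cc1c(OCCCCOc2ccccc2C(=O)O)ccc(C(=O)CC(C)C)c1O` carries a further variation of the same theme, but for this assay compound 2 has no result, "not determined" (no result reported). Where compound 1 stands is therefore defined only by the limit of > 10000 nM in this assay, at which 2 of the 3 values shown sit, so no single number for it is known, and no step between measured compounds can be drawn.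

Compound 4 `Cc1c(OCCCCOc2ccc(F)c(C(=O)O)c2)ccc(C(=O)CC2CCCC2)c1O` is the next compound to be measured. It differs from compound 1 in one place: 3-carboxy-4-fluorophenyl in place of 4-carboxy-2-chlorophenyl on an oxygen on a saturated carbon. For the measured compounds named here, because compound 1 sits at the limit > 10000 nM, there is no measured step that would show what such a change does in this assay, and the values of compound 1 and compound 3 show nothing but limits. The step expected is a step that the limit leaves unreadable from compound 1 to compound 4, none beyond the usual scatter. Compound 4 is estimated at 15000 nM, in a range from 4000 nM to 60000 nM, most probably again reported as a limit.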

Compound 4, half-maximal effective concentration: 2490 nM
Compound 4: middle estimate off by 6.0-fold (0.78 log units), on the high side, outside the stated range (below it).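

Until this point, no compound shown had given a single number in this assay, and compound 4 now gives 2490 nM, which shows that the series can produce a measurable effect. Replacing 4-carboxy-2-chlorophenyl with 3-carboxy-4-fluorophenyl on an oxygen on a saturated carbon, with the rest of the molecule unchanged, gives an at least 4.0-fold lower number from compound 1 to compound 4 (0.60 log units; beyond the scatter), so the substituted ring at this place clearly affects the read-out. The step can be given only as a minimum, because its starting point is a limit rather than a number: the limit of > 10000 nM in this assay, at which 2 of the 4 values shown sit.

The two ring groups differ both in where the carboxy group stands and in the halogen, and the compounds shown do not separate the contribution of the carboxy group's place from that of fluorine entering and chlorine leaving. Going by these compounds, it also remains open how 3-carboxy-4-fluorophenyl would compare with the same ring bearing a tetrazole or an amide in place of the carboxylic acid, and whether the effect would persist with a longer chain linking the two oxygens.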